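This account rests on a few compounds, and the source may have more. Where it says the series, first, only, none or still open, it means among the compounds named here.

In a functional assay on MCF7 cells (Homo sapiens) for antiproliferative activity, read by MTT assay, with a stated time of 48 h (a lower number here means a stronger inhibitor, a higher number a weaker inhibitor), compound 2 `COc1ccc(C(=O)c2ccc(OC)c3c2OC(C)(C)C=C3)c(NC(=O)CN)c1` gives 410 nM. This value lies within the usual scatter of compound 1 `COc1ccc(C(=O)c2ccc(OC)c3c2OC(C)(C)C=C3)c(NC(=O)CO)c1`, which gives 320 nM. It also lies within the scatter of compound 3 `COc1ccc(C(=O)c2ccc3c(c2)C=CC(C)(C)O3)c(NC(=O)CN)c1`, which gives 680 nM. Compound 2 therefore cannot be clearly separated from either of them.

The next compound to be tested, compound 4 `CCNCC(=O)Nc1cc(OC)ccc1C(=O)c1ccc(OC)c2c1OC(C)(C)C=C2`, differs from compound 2 in one place: ethyl in place of hydrogen on an amine nitrogen. In plain words, this is ethyl in place of hydrogen on an amine nitrogen, so amino becomes ethylamino.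

Going by the values given here, no measured pair shows this exact change, and nothing yet reveals how this assay responds to a group added on that nitrogen. The closest evidence is a different change in the same chain, amino in place of hydroxy, which gave a 1.3-fold higher number from compound 1 to compound 2 (0.11 log units; within the scatter). That step is small, but it is only a loose guide to the new change. With so little evidence, no step beyond the scatter is expected, and any drift towards a higher number would be slight. The estimated size is a 1.2-fold higher number from compound 2 to compound 4 (0.07 log units; within the scatter).

For compound 4 the expected value is 480 nM, with an estimated range from 190 nM to 1200 nM.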

Compound 4, half-maximal inhibitory concentration: 5200 nM
The estimate for compound 4 lay 11-fold (1.03 log units) below the measured number; the whole stated range lies below it.
By their numbers in this assay, from the lowest: compounds 1, 2 and 3 (each within the scatter of the next, the first and the last beyond it); then compound 4.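

In this assay, going by these compounds alone, the amine nitrogen at the end of the chain proves far less forgiving than the earlier compounds suggested: ethyl in place of hydrogen there gives a 13-fold higher number from compound 2 to compound 4 (1.10 log units; beyond the scatter) and so weakens the compound sharply. The earlier change on the same chain carbon, amino in place of hydroxy, gave only a 1.3-fold higher number from compound 1 to compound 2 (0.11 log units; within the scatter) and showed no clear separation between those two end groups, whereas ethylamino in place of hydroxy gives a 16-fold higher number from compound 1 to compound 4 (1.21 log units; beyond the scatter) in the same assay. So this end of the chain tolerates amino as well as hydroxy, while the single ethyl on the nitrogen is enough to set compound 4 clearly apart, and nothing given here accounts for that loss of activity.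

As far as these compounds go, it remains open whether any carbon group on this nitrogen has the same effect or whether ethyl is a special case: a methyl, a longer chain such as propyl, or a second ethyl on the same nitrogen would show how the number follows the group. From the compounds shown here alone, it also remains open whether ethylamino would cost as much on the core of compound 3.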